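Swapping a Thiadiazole for Piperidine on the Shared Core

The source may hold more compounds than are shown below. What is called first, only, known or untested is meant among the compounds shown, and "the series" means these compounds.

Measured so far:
compound 1 `CCC(C)(C)Cc1c[nH]c(CCc2ccc(-n3cccn3)cc2)n1` — in a functional assay on HEK293 cells for agonist activity at Bombesin receptor subtype-3 (Homo sapiens), read by luminescence and calcium flux, with a stated time of 10 min (on this read-out lower numbers stand for an effect already at smaller amounts and higher numbers for an effect only at larger amounts of compound), compound 1 gives 106 nM
compound 2 `CCC(C)(C)Cc1c[nH]c(CCc2ccc(-c3csnn3)cc2)n1` — compound 2 gives 104 nM

Compound 2 and compound 1 give numbers that lie within the scatter of each other: a 1.0-fold lower number from compound 1 to compound 2 (0.01 log units; within the scatter). Among the measured compounds shown here, the only measured step thus shows that exchanging one five-membered aromatic ring for another at this position left the read-out unchanged. Compound 3 `CCC(C)(C)Cc1c[nH]c(CCc2ccc(N3CCCCC3)cc2)n1` is the next step from compound 2: piperidin-1-yl in place of 1,2,3-thiadiazol-4-yl on an aromatic carbon. For the measured compounds named here, this change goes beyond the measured one, since a six-membered non-aromatic ring replaces a five-membered aromatic one, and no measured step tests such a swap. The expectation therefore rests only on the unchanged outcome from compound 1 to compound 2, so a step of a 1.4-fold higher number from compound 2 to compound 3 (0.16 log units; within the scatter) is expected, with wide uncertainty. Compound 3 is expected to give about 150 nM, within a range from 50 nM to 500 nM.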

Compound 3, half-maximal effective concentration: 108 nM
Compound 3: middle estimate off by 1.4-fold (0.14 log units), on the high side, within the range that was stated.
By their numbers in this assay, from the lowest: compounds 2, 1 and 3 (each within the scatter of the next).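

In this assay, the read-out stays within the scatter when a six-membered non-aromatic ring takes the place of a five-membered aromatic one on this aromatic carbon (a 1.0-fold higher number from compound 2 to compound 3 (0.02 log units; within the scatter); a 1.0-fold higher number from compound 1 to compound 3 (0.01 log units; within the scatter)). Among the compounds shown here, the earlier pair compared only two aromatic rings, whereas piperidin-1-yl also differs from 1,2,3-thiadiazol-4-yl in ring size, in heavy-atom makeup and in its count of hydrogen-bond acceptors, so for these three groups neither an aromatic ring nor the larger acceptor count is needed to keep the number where it is. Nothing available explains why the three groups give matching numbers.

From the compounds shown here alone, it remains open whether this tolerance extends to groups of a different kind, such as a carboxylic acid, a primary amine or an open butyl chain. Whether a much larger ring system at this position would also leave the number unchanged is equally unknown.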